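Working notes: compound 3 to compound 4, amino for hydroxy

This account rests on a few compounds, and the source may have more. Where it says the series, first, only, none or still open, it means among the compounds named here.

compound 1 `O=c1ccn([C@H]2S[C@@H](CO)C=C2F)c(=O)[nH]1` — a functional assay on Vero cells (Chlorocebus sabaeus); a lower number here means a stronger inhibitor, a higher number a weaker inhibitor: > 100000 nM, a limit of the assay, not a number
compound 2 `Cc1cn([C@H]2S[C@@H](CO)C=C2F)c(=O)[nH]c1=O` — this assay: > 100000 nM, again a limit
compound 3 `OC[C@H]1C=C(F)[C@@H](n2cnc3c(O)ncnc32)S1` — this assay: > 100000 nM, again a limit

Compound 3 stands only at a limit, and so do the other two shown, all three sitting at the limit of > 100000 nM in this assay, at which 3 of the 3 values shown sit. Among the measured compounds shown here, the single measured step, a step that the two limits leave unreadable from compound 1 to compound 2, runs from one limit to another and its size cannot be read. Compound 4 `Nc1ncnc2c1ncn2[C@H]1S[C@@H](CO)C=C1F` differs from compound 3 by amino in place of hydroxy on an aromatic carbon. For the measured compounds named here, no measured step bears on this change. The step is therefore expected to be a number no higher from compound 3 to compound 4 (the limit leaves the size open), with its direction open. Compound 4 is estimated at 100000 nM, within a range of 10000 nM to 300000 nM, and is most likely to return only a limit as well.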

Compound 4, half-maximal inhibitory concentration: > 100000 nM
Compound 4 gave a limit, no number; the forecaster's own chance of this, stated with the estimate: 70%; the middle value lies on the limit itself.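

No step can be read from compound 3 to compound 4, as both values are limits of the assay, not numbers. The compounds shown leave open whether any change on the shared core shifts the read-out in this assay: the limit of > 100000 nM in this assay, at which 4 of the 4 values shown sit.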